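This account rests on a few compounds, and the source may have more. Where it says the series, first, only, none or still open, it means among the compounds named here.

Measured compounds in a functional assay on HT-29 cells (Homo sapiens) for cytotoxicity, read by sulforhodamine B assay; on this read-out lower numbers stand for stronger inhibition of growth and higher numbers for weaker inhibition of growth:
Compound 1, `CC1=CC[C@@H]([C@@](C)(O)CCCC(C)(C)NC(=S)N/N=C\c2ccc(C)cc2)CC1`, gives 80400 nM.
Compound 2, `COc1ccc(/C=N\NC(=S)NC(C)(C)CCC[C@](C)(O)[C@@H]2CC=C(C)CC2)cc1`, gives 35200 nM.
Compound 3, `CC1=CC[C@@H]([C@@](C)(O)CCCC(C)(C)NC(=S)N/N=C\c2ccc(N(C)C)cc2)CC1`, gives > 100000 nM, which is a limit of this assay and not a number.

Compound 3 thus stands at the weak end of the three: it is the only one reported as a limit (the limit of > 100000 nM in this assay, at which 1 of the 3 values shown sits), so its true number is not known. Among the numbered values, a 2.3-fold lower number from compound 1 to compound 2 (0.36 log units; beyond the scatter) is the one step beyond the scatter; an at least 1.2-fold higher number from compound 1 to compound 3 (0.09 log units; that floor lies within the scatter) has a floor that lies within the scatter, while an at least 2.8-fold higher number from compound 2 to compound 3 (0.45 log units; beyond the scatter) is at least modest.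

Compound 4, `CC1=CC[C@@H]([C@@](C)(O)CCCC(C)(C)NC(=S)N/N=C\c2ccccc2[N+](=O)[O-])CC1`, differs from compound 3 by 2-nitrophenyl in place of 4-(dimethylamino)phenyl on a carbon with a double bond to nitrogen. All three measured steps are swaps of the substituent on the aromatic ring attached to the carbon with a double bond to nitrogen, and none of them moved this assay by more than a modest amount. Among the measured compounds shown here, the new aromatic substituent has no measured precedent here, so the step of an at least 1.4-fold lower number from compound 3 to compound 4 (0.15 log units; that floor lies within the scatter) is expected to stay small, with a real chance that compound 4 again reads only as a limit. Compound 4 is therefore estimated at about 70000 nM, with a range from 25000 nM to 200000 nM.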

Compound 4, concentration for total growth inhibition: 16800 nM
Compound 4: the middle estimate sits 4.2-fold (0.62 log units) above what was measured, and the stated range ends above it.
By their numbers in this assay, from the lowest: compound 4; then compound 2; then compound 1. At a limit, above all of these: compound 3.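

In this assay, the substituent on the carbon with a double bond to nitrogen can give a lower number than any earlier aromatic group with a numbered value, as 2-nitrophenyl shows in two steps: a 2.1-fold lower number from compound 2 to compound 4 (0.32 log units; beyond the scatter) and a 4.8-fold lower number from compound 1 to compound 4 (0.68 log units; beyond the scatter). Against 4-(dimethylamino)phenyl, the same swap gives an at least 5.9-fold lower number from compound 3 to compound 4 (0.77 log units; beyond the scatter), and the floor of this step lies beyond the scatter, which separates compound 4 from compound 3 more clearly than the floor of the earlier step separated compound 1 from compound 3. Compound 3 remains a limit of this assay at > 100000 nM, so the full size of its step to compound 4 is not known: the limit of > 100000 nM in this assay, at which 1 of the 4 values shown sits.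

Still open, from the compounds shown here alone, is whether the lower number goes with the nitro group itself or with the change from a 4-substituted phenyl to a 2-substituted phenyl, as the two differ together in every step to compound 4. A 4-nitrophenyl and a 2-methoxyphenyl on the same carbon would separate these two readings.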